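This account rests on a few compounds, and the source may have more. Where it says the series, first, only, none or still open, it means among the compounds named here.

Measured so far in a functional assay on HepG2 cells (Homo sapiens) for cytotoxicity, read by MTT assay, with a stated time of 24 h; on this read-out higher numbers stand for weaker inhibition and lower numbers for stronger inhibition:
- compound 1 `N#Cc1ccc(S(=O)(=O)N2C/C(=C\c3cccnc3)C(=O)/C(=C/c3ccccc3F)C2)cc1`: 6600 nM
- compound 2 `O=C1/C(=C/c2cccnc2)CNC/C1=C\c1ccccc1C(F)(F)F`: 5020 nM
- compound 3 `O=C1/C(=C/c2cccnc2)CN(S(=O)(=O)c2ccc(C(F)(F)F)cc2)C/C1=C\c1ccccc1C(F)(F)F`: 1710 nM

Compound 3 holds the lowest number of the three, and its gaps to compound 2 and compound 1 both lie beyond the scatter. Compound 4 `N#Cc1ccc(S(=O)(=O)N2C/C(=C\c3cccnc3)C(=O)/C(=C/c3ccccc3C(F)(F)F)C2)cc1` has not yet been measured in this assay. It differs from compound 3 in one place: cyano in place of trifluoromethyl on an aromatic carbon. This puts cyano in place of trifluoromethyl on an aromatic carbon, para to a large group, turning 4-(trifluoromethyl)phenyl into 4-cyanophenyl.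

Within the data shown here, no measured pair isolates this change, so the evidence is thin. Compound 1 also carries 4-cyanophenyl, though it differs from compound 4 elsewhere too, and compound 1 gives 6600 nM. On that basis, a small move towards a higher number is expected, with no step beyond the scatter. The estimated change is a 1.5-fold higher number from compound 3 to compound 4 (0.18 log units; within the scatter). For compound 4 the expected value is 2600 nM, with an estimated range of 1100 nM to 6000 nM.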

Compound 4, half-maximal inhibitory concentration: 5060 nM
Estimate against measurement, compound 4: 1.9-fold (0.29 log units) below; measured number inside the range.
By their numbers in this assay, from the lowest: compound 3; then compounds 2, 4 and 1 (each within the scatter of the next).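

In this assay, among these compounds, cyano in place of trifluoromethyl on this aromatic carbon, para to a large group, gives a 3.0-fold higher number from compound 3 to compound 4 (0.47 log units; beyond the scatter), the first single-place step at this position and one beyond the scatter. With 4-cyanophenyl on the sulfonyl group, (4-cyanophenyl)sulfonyl in place of hydrogen on the ring amine nitrogen gives only a 1.0-fold higher number from compound 2 to compound 4 (0.00 log units; within the scatter), so this sulfonyl group does not separate the pair. Trifluoromethyl in place of fluoro on an aromatic carbon gives a 1.3-fold lower number from compound 1 to compound 4 (0.12 log units; within the scatter), also within the scatter, and nothing measured here accounts for any of these steps.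

From the compounds shown here alone, it remains open how a chlorine atom, a methoxy group or plain hydrogen would fare at the same aromatic carbon. Whether the step from trifluoromethyl to cyano recurs with fluoro in place of the other trifluoromethyl group also stays unanswered.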